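A Sulfonyl Group Exchanged on Compound 1

The source may report more compounds than this note shows. Statements on the series, on what has been measured and on what is new or still open speak of the compounds shown alone.

Three compounds have been measured in an ADME assay on a cell-free system (plasma, Rattus norvegicus) for protein binding (on this read-out lower numbers stand for a smaller free fraction and higher numbers for a larger free fraction), so far
- compound 1 `N#Cc1ccc(O[C@H]2CN(S(=O)(=O)c3ccc(C(F)(F)F)cc3)C[C@@]2(O)CO)cc1F` gives 0.033
- compound 2 `N#Cc1ccc(O[C@H]2CN(S(=O)(=O)c3ccc(Cl)cc3Cl)C[C@@]2(O)CN)cc1F` gives 0.036
- compound 3 `N#Cc1ccc(O[C@H]2CN(S(=O)(=O)c3ccc(Cl)cc3Cl)C[C@]2(O)CO)cc1F` gives 0.04

Compound 1 lies within the usual scatter of both other compounds, so the three values form a single group with no meaningful order. Going by the values given here, no pair among them differs in one place only, which leaves the set without a measured step to serve as a guide.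

The account now turns to compound 4 `N#Cc1ccc(O[C@H]2CN(S(=O)(=O)c3ccc(Cl)cn3)C[C@@]2(O)CO)cc1F`, which has not yet been measured. It differs from compound 1 as follows: 5-chloropyridin-2-yl in place of 4-(trifluoromethyl)phenyl on a sulfonyl sulfur. The rest of the core of compound 1 is unchanged.

The closeness of compound 1 at 0.033 and compound 3 at 0.04 argues against a large change, although these two compounds differ in more than one place. The direction is therefore a judgement based on the structural change alone, and a modest rise toward a larger free fraction is expected. The estimated step is a 2.1-fold higher number from compound 1 to compound 4 (0.33 log units; beyond the scatter) in this expected direction. Compound 4 is expected to give 0.07 in this assay with an estimated range from 0.04 to 0.12 for the measurement.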

Compound 4, unbound fraction: 0.18
For compound 4 the middle estimate is 2.6-fold (0.41 log units) below the measured one; measured number outside the range, above it.
By their numbers in this assay, from the lowest: compounds 1, 2 and 3 (each within the scatter of the next); then compound 4.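

In this assay, going by these compounds alone, the exchange on the sulfonyl sulfur gives the first step in the set that can be read for a single change: a 5.5-fold higher number from compound 1 to compound 4 (0.74 log units; beyond the scatter). Within the data shown here, with the rest of the core of compound 1 unchanged, this shows that the group at this position can move the free fraction beyond the scatter, which the earlier compounds could not show, since no two of them differ in one place only. The exchange replaces a six-membered aromatic ring of carbon only with one carrying a hetero atom, adds a hydrogen-bond acceptor and alters the heavy-atom count, and no supporting measurement indicates which of these differences, if any, accounts for the step.

A single step leaves the ring nitrogen and the change of substituent from trifluoromethyl to chlorine unseparated, and a plain chlorophenyl group on the sulfonyl sulfur would be the comparison that could divide the two. On these data alone, it also remains open whether the same exchange would give a similar step on a compound carrying an aminomethyl group in place of the hydroxymethyl group of compound 1.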